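A thiophene for a dimethylphenyl: expecting compound 4

The compounds below may be only part of what the source reports. "The series", "measured", "known", "first", "only" and "open" are said of these compounds alone.

Measured so far:
compound 1 `COc1cccc(-c2nc(C(F)(F)F)n(CC[C@@H](O)C[C@@H](O)CC(=O)O)c2-c2ccc(F)cc2)c1`, 20 nM
compound 2 `Cc1ccc(-c2nc(C(F)(F)F)n(CC[C@@H](O)C[C@@H](O)CC(=O)O)c2-c2ccc(F)cc2)cc1`, 43 nM
compound 3 `Cc1cc(C)cc(-c2nc(C(F)(F)F)n(CC[C@@H](O)C[C@@H](O)CC(=O)O)c2-c2ccc(F)cc2)c1`, 24 nM

The three measured compounds share one core and differ only in the aryl group on it; all were compared in an assay on microsomes from liver for inhibition of 3-hydroxy-3-methylglutaryl-coenzyme A reductase (Rattus norvegicus); a lower number here means a stronger inhibitor, a higher number a weaker inhibitor. Compound 3 stands second highest of the three numbers. Its nearest neighbour is compound 1, the step of a 1.2-fold higher number from compound 1 to compound 3 (0.08 log units; within the scatter) lying within the scatter; its furthest is compound 2, the step of a 1.8-fold lower number from compound 2 to compound 3 (0.25 log units; within the scatter) also within the scatter. For the measured compounds named here, only the step of a 2.2-fold higher number from compound 1 to compound 2 (0.33 log units; beyond the scatter) is modest and beyond the scatter.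

Compound 4 `O=C(O)C[C@H](O)C[C@H](O)CCn1c(C(F)(F)F)nc(-c2cccs2)c1-c1ccc(F)cc1` has not yet been measured. It differs from compound 3 in one place: thiophen-2-yl in place of 3,5-dimethylphenyl on an aromatic carbon. Going by the values given here, no measured step exchanges a six-membered aryl for a five-membered one; the steps among compounds 1, 2 and 3 show only that exchanging one substituted phenyl for another moves this assay by at most a modest amount. On that basis compound 4 is expected to stay near compound 3, with the step of a 1.7-fold higher number from compound 3 to compound 4 (0.22 log units; within the scatter) expected to be small and towards a slightly higher number. The change is larger than any tested here, and the range is set wide. Compound 4 is estimated at 40 nM in this assay, from 12 nM to 130 nM.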

Compound 4, half-maximal inhibitory concentration: 64 nM
For compound 4 the middle estimate is 1.6-fold (0.20 log units) below the measured one; low and high end bracket the measured number.
By their numbers in this assay, from the lowest: compounds 1, 3, 2 and 4 (each within the scatter of the next, the first and the last beyond it).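

In this assay, for the compounds shown here, the aromatic carbon next to the ring atom that bears a 4-fluorophenyl group carries a five-membered aromatic ring with sulfur in compound 4, the first exchange here that changes ring size, and two of its steps, a 2.7-fold higher number from compound 3 to compound 4 (0.43 log units; beyond the scatter) and a 3.2-fold higher number from compound 1 to compound 4 (0.51 log units; beyond the scatter), are modest but lie beyond the scatter, whereas the exchanges among the substituted phenyl groups reached that range only once. The loss is not general to all the six-membered rings, since the comparison with the 4-methylphenyl group stays inside the scatter, at a 1.5-fold higher number from compound 2 to compound 4 (0.17 log units; within the scatter), so compound 4 cannot be ranked apart from compound 2. Nothing available here accounts for the size of these steps.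

The compounds shown leave open whether the outcome belongs to the five-membered ring as such or to thiophen-2-yl alone, which furan-2-yl, thiophen-3-yl or a methylthiophene at this position could test. They also leave open whether a pyridine ring, with nitrogen in place of a ring carbon, or a methoxy group on the thiophene would sit with compound 1 or with compound 4.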